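A few compounds are considered here, and "the series" means these few. Any claim that something is new, unique, unknown or untested is made for them only; others in the source may bear on it.

The study concerns two measured analogues and one still to be measured. Compound 1 `Cc1ccc(CN2C(=O)S/C(=C\c3cccc(N)c3)C2=O)cc1` and compound 2 `Nc1cccc(/C=C2\SC(=O)N(Cc3ccccc3)C2=O)c1` share one core and differ at a single aromatic carbon. In a functional assay on FM3A cells (Mus musculus) for cytotoxicity, read by cell counting, with a stated time of 2 days (a higher number here means a weaker inhibitor, a lower number a stronger inhibitor), compound 1 gives 158000 nM. For compound 2 this assay reports only a limit, > 250000 nM, and not a number. The step of an at least 1.5-fold higher number from compound 1 to compound 2 (0.19 log units; that floor lies within the scatter) therefore cannot be sized beyond its floor, and that floor sits within the scatter; what stands behind it is that one of the two values rests at the limit of > 250000 nM in this assay, at which 1 of the 2 values shown sits. Compound 3 `Nc1cccc(/C=C2\SC(=O)N(Cc3ccc(C(F)(F)F)cc3)C2=O)c1` differs from compound 2 by trifluoromethyl in place of hydrogen on an aromatic carbon. Going by the values given here, the only measured step that bears on this place is the exchange of methyl for hydrogen, and it set a floor rather than a size. Compound 3 is thus expected to remain in the same weak region, with a number no higher from compound 2 to compound 3 (the limit leaves the size open) as the expected step, small and without a clear direction. The estimate for compound 3 in this assay is 250000 nM, between 90000 nM and 700000 nM.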

Compound 3, half-maximal inhibitory concentration: > 250000 nM
Compound 3: a limit, no number; the forecaster's own chance of this, stated with the estimate: 60%; the middle value lies on the limit itself.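

In this assay compound 3 gives > 250000 nM, a limit and not a number, so trifluoromethyl at this aromatic carbon yields no readable value, just as hydrogen did. The exchange of methyl for trifluoromethyl gives an at least 1.5-fold higher number from compound 1 to compound 3 (0.19 log units; that floor lies within the scatter), a second floor that stays within the scatter, while the steps between the two compounds held at the limit cannot be read. Hydrogen and trifluoromethyl at this place therefore cannot be told apart, and the values now gather at one limit: the limit of > 250000 nM in this assay, at which 2 of the 3 values shown sit.

On these data alone, whether an amine, a carboxylic acid or a longer chain at this aromatic carbon would give a number beyond the scatter from compound 1 remains open. As far as these compounds go, the true size of the steps to compound 2 and compound 3 also stays open.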